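The compounds below may be only part of what the source reports. "The series", "measured", "known", "first", "only" and "open" are said of these compounds alone.

Compound 1 `CCCc1c(COc2ccc(C(=O)C(C)Cc3nnn[nH]3)cc2)ccc(C(C)=O)c1O` is the weaker of the two compounds measured here. In a functional assay on ileum (Cavia porcellus) with cysteinyl leukotriene receptor (Homo sapiens) as the target (a higher number here means a more potent compound, by a factor of ten per unit of this negative logarithm, a lower number a less potent compound), compound 1 gives 7.18, while compound 2 `CCc1c(COc2ccc(C(=O)CC(C)(C)Cc3nnn[nH]3)cc2)ccc(C(C)=O)c1O`, which carries a different chain on the carbonyl carbon and a different substituent on the core, gives 8.09 in this assay, a higher number that lies beyond the usual scatter. Compound 3 `CCCc1c(COc2ccc(C(=O)CCCCc3nnn[nH]3)cc2)ccc(C(C)=O)c1O` has not yet been measured. It differs from compound 1 in one place: 4-(1H-tetrazol-5-yl)butyl in place of 1-((1H-tetrazol-5-yl)methyl)ethyl on a carbonyl carbon. For the measured compounds named here, no measured pair mirrors this exact change, so the expected step rests only on the two values given. The chain of compound 2, which is also longer than that of compound 1, goes with a higher value, so a modest gain is expected, and the step from compound 1 to compound 3 in this assay is estimated at a number 0.32 log units higher from compound 1 to compound 3 (beyond the scatter). Compound 3 is therefore expected to reach about 7.5 in this assay, with a range from 6.8 to 8.2.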

Compound 3, negative logarithm of the antagonist equilibrium constant: 7.28
The estimate for compound 3 lay 0.22 log units above the measured number; the measured number falls inside the stated range.
By their numbers in this assay, from the lowest: compounds 1 and 3 (each within the scatter of the next); then compound 2.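

With the core of compound 1 held fixed, placing 4-(1H-tetrazol-5-yl)butyl in place of 1-((1H-tetrazol-5-yl)methyl)ethyl on a carbonyl carbon gives a number 0.10 log units higher from compound 1 to compound 3 (within the scatter) in this assay, so this assay does not separate the two chains. For the compounds shown here, this is the first comparison in which only that chain changes, as compound 2 differs from compound 1 and compound 3 in more than one place and its higher number cannot be assigned to its chain alone. Nothing given here explains why the two chains read alike.

As far as these compounds go, whether the chain of compound 2 would keep its number on the core of compound 1 remains open. Also open, from the compounds shown here alone, is how a longer chain on the carbonyl carbon, or a carboxylic acid in place of the tetrazole, would read in this assay.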